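This account rests on a few compounds, and the source may have more. Where it says the series, first, only, none or still open, it means among the compounds named here.

In an ADME assay (liver) for metabolic stability, with Liver microsome (Homo sapiens) as the target, read by LC-MS, using microsomes, tested at 1 uM (a lower number here means slower removal, a higher number faster removal of the compound), two compounds have been measured so far. Compound 1 `CCc1c(C)[nH]c2cc(OC)c(Cl)cc2c1=O`, which carries ethyl on the aromatic carbon in question, gives 56 mL.min-1.g-1. Compound 2 `COc1cc2[nH]c(C)c(-c3cccnc3)c(=O)c2cc1Cl`, with pyridin-3-yl at that place, gives 15 mL.min-1.g-1, the lower of the two numbers. Compound 3 `COc1cc2[nH]c(C)c(-c3ccncc3)c(=O)c2cc1Cl` has not yet been measured. It has the same atoms as compound 2, joined differently: pyridin-4-yl in place of pyridin-3-yl on an aromatic carbon. In words, pyridin-4-yl stands in place of pyridin-3-yl on an aromatic carbon, ortho to a methyl group.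

Among the compounds with values here, only one measured step bears on this change, and only indirectly. Going from ethyl to pyridin-3-yl gave a 3.7-fold lower number from compound 1 to compound 2 (0.57 log units; beyond the scatter), a modest step beyond the scatter. That step replaced a chain with a ring, whereas here one ring replaces another with the same counts. Within the data shown here, no measured pair compares pyridin-4-yl with pyridin-3-yl, so no step beyond the scatter is expected, in either direction, although the data cannot exclude one. The estimated step is no change at the digits printed from compound 2 to compound 3 (within the scatter). For compound 3 the expected value is 15 mL.min-1.g-1, with an estimated range from 7 mL.min-1.g-1 to 32 mL.min-1.g-1.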

Compound 3, intrinsic clearance in microsomes: 15 mL.min-1.g-1
Estimate against measurement, compound 3: no gap at the digits printed; measured number inside the range.
By their numbers in this assay, from the lowest: compounds 2 and 3 (each within the scatter of the next); then compound 1.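

In this assay, within the data shown here, pyridin-4-yl in place of pyridin-3-yl gives no change at the digits printed from compound 2 to compound 3 (within the scatter), so at this aromatic carbon, ortho to a methyl group, the two groups cannot be told apart in this read-out, and the nitrogen's place in the ring shows no effect in this pair. Pyridin-4-yl in place of ethyl gives a 3.7-fold lower number from compound 1 to compound 3 (0.57 log units; beyond the scatter), so the modest step seen earlier with a single ring now appears with a second one, and compound 2 and compound 3 both stand apart from compound 1 by the same margin. Nothing available explains why the two rings read alike or why each differs from ethyl.

The compounds shown leave open whether pyridin-2-yl or plain phenyl at this carbon would read like the two rings tested, and whether a longer chain than ethyl or an amine would lie nearer compound 1 or nearer compound 3. They also leave open whether the match between pyridin-3-yl and pyridin-4-yl would hold if the methyl group beside the change or the chlorine on the shared core were replaced.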